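The compounds below may be only part of what the source reports. "The series", "measured", "known", "first", "only" and "open" are said of these compounds alone.

Compound 2 `CCCCNC(=O)c1ccc2c(ccn2-c2ncc3c(n2)N(C2CCCC2)[C@H](CC)C(=O)N3C)c1` gives 683 nM in a functional assay on Huh-7 cells (Homo sapiens) for antiproliferative activity, read by CCK-8 assay, with a stated time of 72 h (on this read-out lower numbers stand for stronger inhibition of growth and higher numbers for weaker inhibition of growth), the second highest of the three numbers measured. Compound 1 `CC[C@@H]1C(=O)N(C)c2cnc(-n3ccc4cc(C(=O)NC5CCCC5)ccc43)nc2N1C1CCCC1` gives 259 nM in this assay, and compound 3 `CCC1C(=O)N(C)c2cnc(Nc3ccc(S(=O)(=O)NC)cc3)nc2N1c1ccn(C)n1` gives 11900 nM. Among the measured compounds shown here, compound 1 and compound 2 share a core and differ only in the group on the amide-type nitrogen, and that step, a 2.6-fold higher number from compound 1 to compound 2 (0.42 log units; beyond the scatter), is the one measured step that bears on the change considered here. Compound 4 `CCCNC(=O)c1ccc2c(ccn2-c2ncc3c(n2)N(C2CCCC2)[C@H](CC)C(=O)N3C)c1` differs from compound 2 by hydrogen in place of methyl on a saturated chain carbon, three bonds along the chain from an amide-type nitrogen. Cut one bond further out, this reads butyl to propyl, a smaller change than the ring-to-chain swap seen before, so the expected step is a 1.2-fold higher number from compound 2 to compound 4 (0.07 log units; within the scatter), not beyond the scatter. Compound 4 is therefore expected to give 800 nM in this assay, within a range from 350 nM to 1800 nM.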

Compound 4, concentration for 50% growth inhibition: 689 nM
Compound 4: middle estimate off by 1.2-fold (0.06 log units), on the high side, and the stated range covers the measured number.
By their numbers in this assay, from the lowest: compound 1; then compounds 2 and 4 (each within the scatter of the next); then compound 3.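

Shortening the chain on the amide-type nitrogen from butyl to propyl leaves the number in place (a 1.0-fold higher number from compound 2 to compound 4 (0.00 log units; within the scatter)), so this outermost methyl makes no difference that this assay can detect. The cyclopentyl of compound 1 still stands apart from the propyl chain (a 2.7-fold higher number from compound 1 to compound 4 (0.42 log units; beyond the scatter)), a gap that the butyl chain showed too. No other measurement here speaks to what lies behind these results. As far as these compounds go, whether an ethyl group, a longer chain such as hexyl, or a chain ending in an amine would read the same stays open.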